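Cytotoxicity of Three Measured Compounds and One Untested

The source may report more compounds than this note shows. Statements on the series, on what has been measured and on what is new or still open speak of the compounds shown alone.

Three compounds were tested in a functional assay on MT4 cells (Homo sapiens) for cytotoxicity; on this read-out lower numbers stand for higher toxicity in this test and higher numbers for lower toxicity in this test:
Compound 1 `CCCCSc1nc(O)cc(C(C)c2c(F)cccc2F)n1` gave > 200000 nM, a limit of this assay.
Compound 2 `CCC(C)Sc1nc(O)cc(C(C)c2c(F)cccc2F)n1` gave > 200000 nM, likewise a limit.
Compound 3 `CCC(C)Sc1nc(O)c(C)c(C(C)c2c(F)cccc2F)n1` gave > 200000 nM, also a limit.

The change butyl in place of sec-butyl on a sulfur made a step that the two limits leave unreadable from compound 2 to compound 1. The change methyl in place of hydrogen on an aromatic carbon made a step that the two limits leave unreadable from compound 2 to compound 3. Both are unreadable because of the limit of > 200000 nM in this assay, at which 3 of the 3 values shown sit.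

Compound 4 `CCCCSc1nc(O)c(C)c(C(C)c2c(F)cccc2F)n1` has not been measured. It differs from compound 3 by butyl in place of sec-butyl on a sulfur, the same change as from compound 2 to compound 1, at the same place. From compound 3 to compound 4 a step that the limit leaves unreadable from compound 3 to compound 4 is expected, resting on the step that the two limits leave unreadable from compound 2 to compound 1 and on (the limit of > 200000 nM in this assay, at which 3 of the 3 values shown sit). Compound 4 is therefore estimated at 300000 nM, most likely reported again only as a limit.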

Compound 4, half-maximal cytotoxic concentration: 112000 nM
Estimate against measurement, compound 4: 2.7-fold (0.43 log units) above; the whole stated range lies above it.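

In this assay, butyl in place of sec-butyl on a sulfur gave an at least 1.7-fold lower number from compound 3 to compound 4 (0.25 log units; that floor lies within the scatter), and methyl in place of hydrogen on an aromatic carbon gave an at least 1.7-fold lower number from compound 1 to compound 4 (0.25 log units; that floor lies within the scatter). On the core of compound 3, the butyl change can therefore be given a size, though only as a floor, and this does not show that the same change carries over from the core of compound 2. The matching step on the core of compound 2 and the other earlier steps cannot be read: the limit of > 200000 nM in this assay, at which 3 of the 4 values shown sit.

The compounds shown leave open how a longer chain, such as hexyl, would read on the sulfur of either core. They also leave open how an amine in place of the methyl on the aromatic carbon would read in this assay.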